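This account rests on a few compounds, and the source may have more. Where it says the series, first, only, none or still open, it means among the compounds named here.

Measured compounds:
compound 1, `CCc1cccc2c(=O)c(-c3nn[nH]n3)c[nH]c12`: 0.312 mg/kg
compound 2, `O=C(O)c1cnc2c(C(F)(F)F)cccc2c1`: 50 mg/kg
compound 3, `COc1ccc2c(O)c(C(=O)O)cnc2c1`: > 50 mg/kg, which is a limit of the assay and not a number

All three were tested in a functional assay on the whole organism (strain Sprague-Dawley) for inhibition, with Rattus norvegicus as the target; a lower number here means that less compound is needed, a higher number that more compound is needed for the effect. Among the two plain numbers, compound 1 stands lowest with 0.312 mg/kg, and the nearest, compound 2 with 50 mg/kg, sits far higher, well beyond the usual scatter. For compound 3 the assay reported only (the limit of > 50 mg/kg in this assay, at which 1 of the 3 values shown sits), so no number is known for it.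

Compound 4 is `Cc1cccc2c(=O)c(-c3nn[nH]n3)c[nH]c12` and has not yet been measured. It differs from compound 1 in one place only: hydrogen in place of methyl on a saturated chain carbon bound to an aromatic carbon. Among the measured compounds shown here, no pair of measured compounds shows a change of this kind, so the expectation rests on compound 1 alone. For the measured compounds named here, the change is small, and no measured step suggests otherwise, so a step of little size is expected. Compound 4 is expected to give about 0.4 mg/kg, within a range from 0.15 mg/kg to 1.2 mg/kg. This estimate means a step of a 1.3-fold higher number from compound 1 to compound 4 (0.11 log units; within the scatter), expected to stay within the usual scatter.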

Compound 4, minimum effective dose: > 5 mg/kg
Compound 4: a limit, no number (the forecaster's own chance of this, stated with the estimate: 3%); middle value at least 12-fold (1.09 log units) away from the limit.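

In this assay, compound 4 is reported only as a limit and not as a number: the limit of > 5 mg/kg in this assay, at which 1 of the 4 values shown sits.

Even so, the change from ethyl to methyl, on a saturated chain carbon bound to an aromatic carbon, is not as minor as its single carbon suggests, giving an at least 16-fold higher number from compound 1 to compound 4 (1.20 log units; beyond the scatter). This is the only pair shown that tests this place, and it shows that the effect in the whole animal can depend strongly on the length of this small chain, although the true size of the step stays unknown.

The compounds shown leave open whether a longer chain, such as propyl, would need less compound or more. They also do not tell how an amine or a methoxy group at this place would compare with ethyl on the same core.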